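The source may report more compounds than this note shows. Statements on the series, on what has been measured and on what is new or still open speak of the compounds shown alone.

Measured compounds:
- compound 1, `Cc1ccc2nc([C@H](CC3CCNCC3)N3C(=O)CN(c4ccc(Oc5ccccc5)cc4)C3=O)n(C)c2c1`: 64000 nM
- compound 2, `Cc1ccc2nc([C@H](CC3CCN(C(=O)C4CCCC4)CC3)N3C(=O)CN(c4ccc(Oc5ccccc5)cc4)C3=O)n(C)c2c1`: 30 nM
- compound 3, `CC(=O)N1CCC(C[C@@H](c2nc3ccccc3n2C)N2C(=O)CN(c3ccc(Oc4ccccc4)cc3)C2=O)CC1`: 740 nM

In an assay on isolated protein for antagonist activity at Bile acid receptor (Homo sapiens), read by TR-FRET and LanthaScreen (on this read-out higher numbers stand for weaker inhibition and lower numbers for stronger inhibition), compound 3 stands second highest of the three numbers. Its nearest neighbour is compound 2, whose number is lower beyond the scatter; furthest is compound 1, whose number is higher beyond the scatter. For the measured compounds named here, the one step available, a 2100-fold lower number from compound 1 to compound 2 (3.33 log units; beyond the scatter), concerns the ring amine and is large.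

Compound 4, `CC(=O)N1CCC(C[C@@H](c2nc3ccc(Cl)cc3n2C)N2C(=O)CN(c3ccc(Oc4ccccc4)cc3)C2=O)CC1`, differs from compound 3 by chloro in place of hydrogen on an aromatic carbon. Going by the values given here, no measured pair isolates a change on that aromatic carbon: the cyclopentylcarbonyl step from compound 1 to compound 2 does not bear on it, and compounds 1 and 2 differ from compound 3 in more than one place, so their values give no clean reading of a substituent on the 1-methyl-1H-benzimidazol-2-yl group. The expectation therefore rests on the step being small: a chloro-for-hydrogen change on an aromatic carbon, with nothing in the series showing it to move the number by much.

For compound 4 in this assay the estimate is 450 nM, within 120 nM to 1700 nM, an expected step of a 1.6-fold lower number from compound 3 to compound 4 (0.22 log units; within the scatter) against compound 3, near the scatter.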

Compound 4, half-maximal inhibitory concentration: 3500 nM
Estimate against measurement, compound 4: 7.8-fold (0.89 log units) below, and the stated range ends below it.
By their numbers in this assay, from the lowest: compound 2; then compound 3; then compound 4; then compound 1.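

In this assay, for the compounds shown here, chloro in place of hydrogen on this aromatic carbon gives a 4.7-fold higher number from compound 3 to compound 4 (0.67 log units; beyond the scatter) and is the first clean reading of any change at this carbon, which shows that the site is not indifferent to substitution. Going from 1-methyl-1H-benzimidazol-2-yl to 6-chloro-1-methyl-1H-benzimidazol-2-yl weakens inhibition beyond the scatter, although this modest step is far smaller than a 2100-fold lower number from compound 1 to compound 2 (3.33 log units; beyond the scatter) at the ring amine. Nothing measured in the series accounts for the loss.

As far as these compounds go, it remains open whether the loss is specific to chloro or would also follow from fluoro, methyl or methoxy on the same aromatic carbon, and whether chloro elsewhere on this six-membered aromatic ring would read the same way. Also open, from the compounds shown here alone, is whether the step carries over to compounds bearing the cyclopentylcarbonyl group of compound 2, which differs from compound 3 in more than one place and so gives no reading of this change.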